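The source may hold more compounds than are shown below. What is called first, only, known or untested is meant among the compounds shown, and "the series" means these compounds.

Working notes on the series. In a functional assay on HCT-116 cells (Homo sapiens) for antiproliferative activity, read by sulforhodamine B assay, with a stated time of 72 h (on this read-out higher numbers stand for weaker inhibition and lower numbers for stronger inhibition), compound 1 `COc1ncc(-c2ccc3ncc(NCc4ccccc4)c(OC)c3c2)cc1NS(=O)(=O)c1ccc(F)cc1F` gives 16800 nM and compound 2 `COc1ncc(-c2ccc3ncc(NCC4CCCCC4)c(OC)c3c2)cc1NS(=O)(=O)c1ccc(F)cc1F` gives 13600 nM. Cyclohexyl in place of phenyl is a 1.2-fold lower number from compound 1 to compound 2 (0.09 log units; within the scatter), so these two stand level. Compound 3 `COc1ncc(-c2ccc3ncc(NC(=O)CN4CCCC(O)C4)c(OC)c3c2)cc1NS(=O)(=O)c1ccc(F)cc1F`, with ((3-hydroxypiperidin-1-yl)methyl)carbonyl on a nitrogen on an aromatic ring, gives 1770 nM. Compound 2 thus stands with compound 1, clear of compound 3 on the high side.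

Compound 4 `COc1ncc(-c2ccc3ncc(NC(C)=O)c(OC)c3c2)cc1NS(=O)(=O)c1ccc(F)cc1F` has acetyl in place of cyclohexylmethyl on a nitrogen on an aromatic ring.

Within the data shown here, the closest precedent is a 7.7-fold lower number from compound 2 to compound 3 (0.89 log units; beyond the scatter), a modest step that also puts a carbonyl on that nitrogen. It is matched by a 9.5-fold lower number from compound 1 to compound 3 (0.98 log units; beyond the scatter). Among the measured compounds shown here, compound 3 is the only measured compound with a carbonyl there, so the trend rests on one compound. For the measured compounds named here, no measured compound separates the carbonyl from the hydroxypiperidinyl part, and compound 4 lacks that part. Going by the values given here, a step in the same direction is therefore expected, probably somewhat smaller than the one to compound 3. In this assay the expected step is a 3.9-fold lower number from compound 2 to compound 4 (0.59 log units; beyond the scatter). For compound 4 the estimated value is 3500 nM, with an expected range of 1000 nM to 11000 nM.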

Compound 4, half-maximal inhibitory concentration: 550 nM
For compound 4 the middle estimate is 6.4-fold (0.80 log units) above the measured one; the measured number lies below the stated range.
By their numbers in this assay, from the lowest: compound 4; then compound 3; then compounds 2 and 1 (each within the scatter of the next).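

In this assay, a carbonyl on this nitrogen now goes with a lower number in two compounds rather than one: acetyl in place of cyclohexylmethyl gives a 25-fold lower number from compound 2 to compound 4 (1.39 log units; beyond the scatter), and acetyl in place of benzyl gives a 31-fold lower number from compound 1 to compound 4 (1.48 log units; beyond the scatter), both large steps. The carbonyl can also now be read apart from the hydroxypiperidinyl part: hydrogen in place of 3-hydroxypiperidin-1-yl on a saturated chain carbon bound to a carbonyl carbon gives a 3.2-fold lower number from compound 3 to compound 4 (0.51 log units; beyond the scatter), so that part is not required for a low number here. Across the four compounds, both with a carbonyl on this nitrogen stand lower than both with a saturated chain carbon there, none goes against this, and acetyl, with the fewest heavy atoms of the groups compared, gives the lowest number.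

Nothing at hand explains why acetyl on this nitrogen goes with the lower number. An ethyl group on this nitrogen would separate the carbonyl from the size of the group, while a propanoyl group would show whether the low number holds with a longer chain on the carbonyl.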